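The compounds below may be only part of what the source reports. "The series", "measured", "known", "first", "only" and "open" are said of these compounds alone.

Of the compounds shown here, three in this set have been tested in an assay on microsomes from liver for inhibition of sterol O-acyltransferase 1 (Rattus norvegicus); a higher number here means a weaker inhibitor, a lower number a stronger inhibitor. Compound 1, `C[C@@]1(O)CC(=O)OC(CSc2nc(-c3ccc(Cl)cc3)c(-c3ccc(Cl)cc3)[nH]2)C1`, gives 180 nM. Compound 2, `CC1=CC(=O)OC(CSc2nc(-c3ccccc3Cl)c(-c3ccccc3Cl)[nH]2)C1`, gives 1700 nM. Compound 3, `O=C1CC(O)CC(CSc2nc(-c3ccccc3)c(-c3ccccc3)[nH]2)O1`, gives 910 nM. On these numbers compound 3 stands second highest of the three: its nearest neighbour is compound 2, whose number lies within the usual scatter of it, while compound 1 sits furthest away with a number that is lower by more than the scatter allows. No two of the measured compounds differ in only one place, so no single step can be read off between them; what can be said is only what the three values show side by side.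

Compound 4, `c1ccc(-c2nc(SCC3CCCCC3)[nH]c2-c2ccccc2)cc1`, is the next compound and has not yet been measured in this assay. It is related to compound 3 by one exchange: a group of 6 heavy atoms (6 carbon; one six-membered non-aromatic ring of carbon only) in place of a group of 8 heavy atoms (5 carbon, 3 oxygen; one six-membered non-aromatic ring with 1 hetero atom), on a saturated chain carbon bound to a sulfur. Among the measured compounds shown here, every measured compound here carries a ring with oxygen on that side chain, so there is no direct precedent for the cyclohexyl. The step from compound 3 to compound 4 in this assay is expected to be modest, a 1.6-fold higher number from compound 3 to compound 4 (0.22 log units; within the scatter), leaning toward a higher number but not clearly beyond the scatter. For compound 4 the estimate in this assay is 1500 nM, within a range from 400 nM to 6000 nM.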

Compound 4, half-maximal inhibitory concentration: 100 nM
Estimate against measurement, compound 4: 15-fold (1.18 log units) above; measured number outside the range, below it.
By their numbers in this assay, from the lowest: compounds 4 and 1 (each within the scatter of the next); then compounds 3 and 2 (each within the scatter of the next).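

In this assay, among the compounds shown here, replacing the ring with oxygen by cyclohexyl, on a saturated chain carbon bound to a sulfur, gives a 9.1-fold lower number from compound 3 to compound 4 (0.96 log units; beyond the scatter), the first step in this set that can be read in one place. It shows that the ring with oxygen, with its hydrogen-bond donor, its hydrogen-bond acceptors and its double bond outside aromatic rings, is not required at this position for a low number, as a ring of carbon only, with 0 hydrogen-bond donors and 0 hydrogen-bond acceptors, gives a lower number on the same core. No measurement shown here bears on what lies behind this step.

The ring oxygen, the carbonyl and the hydroxyl all leave together in this single exchange, so the compounds shown cannot say which of them matters, and a tetrahydropyranyl ring, a cyclohexyl carrying a hydroxyl or a plain hexyl chain would be needed to separate them. Going by these compounds, it also remains open whether the same exchange would give a step of similar size on the chlorine-bearing cores of compound 1 and compound 2.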